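The compounds below may be only part of what the source reports. "The series", "measured", "known", "first", "only" and "open" are said of these compounds alone.

In an ADME assay on BaF3 cells (Mus musculus) for cytotoxicity, read by CellTiter-Glo and CCK-8 assay, with a stated time of 72 h; on this read-out lower numbers stand for stronger inhibition of growth and higher numbers for weaker inhibition of growth:
- Compound 1 `CCC(=O)Nc1ccc(C(=O)Nc2ccc(C)c(Nc3nccc(-c4cccnc4)n3)c2)cc1`: > 10000 nM
- Compound 2 `C=CC(=O)Nc1ccc(C(=O)Nc2ccc(C)c(Nc3nccc(-c4cccnc4)n3)c2)cc1`: 5600 nM
- Compound 3 `C=CC(=O)N(CCN(C)C)Cc1ccc(C(=O)Nc2ccc(C)c(Nc3nccc(-c4cccnc4)n3)c2)cc1`: > 10000 nM

The value of compound 3 is a limit of the assay, not a number. It shares (the limit of > 10000 nM in this assay, at which 2 of the 3 values shown sit), and only compound 2 has a true number.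

Compound 4 `CCCC(=O)N(CCN(C)C)Cc1ccc(C(=O)Nc2ccc(C)c(Nc3nccc(-c4cccnc4)n3)c2)cc1` differs from compound 3 in one place: propyl in place of vinyl on a carbonyl carbon. In words, this is propyl in place of vinyl on a carbonyl carbon.

The closest measured change is a similar swap in the opposite sense, vinyl in place of ethyl on a carbonyl carbon: an at least 1.7-fold lower number from compound 1 to compound 2 (0.25 log units; that floor lies within the scatter). The other relevant step, which adds the side chain of compound 3, is an at least 1.7-fold higher number from compound 2 to compound 3 (0.25 log units; that floor lies within the scatter). Neither shows a size beyond the scatter.

Judging from the small floor of an at least 1.7-fold lower number from compound 1 to compound 2 (0.25 log units; that floor lies within the scatter), no step beyond the scatter is expected in this assay, and a result reported only as a limit is likely. The estimated step is a step that the limit leaves unreadable from compound 3 to compound 4.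

For compound 4 the expected value is 12000 nM, with an estimated range of 7000 nM to 20000 nM.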

Compound 4, concentration for 50% growth inhibition: > 10000 nM
Compound 4: no number, only a limit; the forecaster's own chance of this, stated with the estimate: 85%; the middle value does not contradict the limit.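

In this assay compound 4 gives > 10000 nM, which is a limit of the assay and not a number. Within the data shown here, measured against compound 2, the only compound here with a true number, the result is an at least 1.7-fold higher number from compound 2 to compound 4 (0.25 log units; that floor lies within the scatter), while the steps to compound 4 from compound 3 and from compound 1 cannot be read, as both ends of each are limits. Propyl in place of vinyl on this carbonyl carbon therefore shows no readable change, and the set now sits mostly at one edge of the read-out: the limit of > 10000 nM in this assay, at which 3 of the 4 values shown sit.

On these data alone, whether a longer chain or an amine on this carbonyl carbon would give a true number in this assay remains open. Also open, as far as these compounds go, is whether the vinyl group matters at all in compounds carrying the 2-(dimethylamino)ethyl side chain.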